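A few compounds are considered here, and "the series" means these few. Any claim that something is new, unique, unknown or untested is made for them only; others in the source may bear on it.

Measured compounds in a functional assay on K562 cells (Homo sapiens), read by MTT assay, with a stated time of 72 h; a lower number here means a stronger inhibitor, a higher number a weaker inhibitor:
compound 1 `C#Cc1cn([C@@H]2O[C@H](CO)[C@@H](O)[C@H]2O)c2ncnc(NC)c12`, 1380 nM
compound 2 `C#Cc1cn([C@@H]2O[C@H](CO)[C@@H](O)[C@H]2O)c2ncnc(OC)c12`, 380 nM
compound 3 `CNc1ncnc2c1c(-c1ccco1)cn2[C@@H]1O[C@H](CO)[C@@H](O)[C@H]1O`, 15100 nM

Compound 3 is the weakest of the three in this assay: an 11-fold higher number from compound 1 to compound 3 (1.04 log units; beyond the scatter), the difference between the two cores being (furan-2-yl in place of ethynyl on an aromatic carbon). Within the core of compound 1, the change methoxy in place of methylamino on an aromatic carbon gave a 3.6-fold lower number from compound 1 to compound 2 (0.56 log units; beyond the scatter).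

Compound 4 `COc1ncnc2c1c(-c1ccco1)cn2[C@@H]1O[C@H](CO)[C@@H](O)[C@H]1O` is not yet measured in this assay. Within the data shown here, it differs from compound 3 by methoxy in place of methylamino on an aromatic carbon, the same change, at the same place, as the one from compound 1 to compound 2. That change is seen only once among the measured compounds, so a step of the same kind is expected here: a 3.6-fold lower number from compound 3 to compound 4 (0.56 log units; beyond the scatter), which rests on a 3.6-fold lower number from compound 1 to compound 2 (0.56 log units; beyond the scatter). Compound 4 is therefore estimated at 4200 nM, with a likely range from 1500 nM to 12000 nM.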

Compound 4, half-maximal inhibitory concentration: 380 nM
For compound 4 the middle estimate is 11-fold (1.04 log units) above the measured one; the measured number lies below the stated range.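

In this assay, methoxy in place of methylamino gave a 40-fold lower number from compound 3 to compound 4 (1.60 log units; beyond the scatter), so this change does not carry over at a fixed size from one core to the other: the same change on two cores in this assay, a 3.6-fold lower number (0.56 log units; beyond the scatter) from compound 1 to compound 2 and a 40-fold lower number (1.60 log units; beyond the scatter) from compound 3 to compound 4, 11-fold (1.04 log units) apart, beyond the scatter of two such steps

Read the other way, furan-2-yl in place of ethynyl gave no change at the digits printed from compound 2 to compound 4 (within the scatter) with methoxy present, so the two changes do not add independently across these compounds: the same change on two cores in this assay, an 11-fold higher number (1.04 log units; beyond the scatter) from compound 1 to compound 3 and no change at the digits printed (within the scatter) from compound 2 to compound 4, 11-fold (1.04 log units) apart, beyond the scatter of two such steps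

The methoxy change lowers the number on both cores, but two pairs give no cause for the difference in size and no rule for a further core.

As far as these compounds go, it remains open whether an ethoxy or dimethylamino group on that aromatic carbon would behave like methoxy or like methylamino. From the compounds shown here alone, it also remains open whether a phenyl group in place of ethynyl or furan-2-yl would show the same dependence.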